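The compounds below may be only part of what the source reports. "The series", "measured", "known", "first", "only" and "open" are said of these compounds alone.

Of the compounds shown here, three built on the shared core have been measured in a functional assay on LoVo cells (Homo sapiens) for inhibition, read by MTT assay, with a stated time of 48 h (on this read-out higher numbers stand for weaker inhibition and lower numbers for stronger inhibition), so far, and all of them carry selenium. Compound 1 `COc1ccc(N(C)c2nc(C)nc3ccccc23)cc1OCCCCCC[Se]C#N` gives 8580 nM as its value, compound 2 `COc1ccc(N(C)c2nc(C)nc3ccccc23)cc1C(=O)NCC[Se]C#N` gives 561 nM as its value, and compound 3 `COc1ccc(N(C)c2nc(C)nc3ccccc23)cc1[Se]C#N` gives 73 nM and so stands lowest of the three, making it the strongest inhibitor among them.

Compound 4 `COc1ccc(N(C)c2nc(C)nc3ccccc23)cc1OCCN` differs from compound 3 by a group of 4 heavy atoms (2 carbon, 1 nitrogen, 1 oxygen; no ring) in place of a group of 3 heavy atoms (1 carbon, 1 nitrogen, 1 selenium; no ring), on an aromatic carbon and the entering group is 2-aminoethoxy, so the selenium is gone.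

The measured steps all keep selenium and change only the group that carries it: a 120-fold lower number from compound 1 to compound 3 (2.07 log units; beyond the scatter) is large, a 15-fold lower number from compound 1 to compound 2 (1.18 log units; beyond the scatter) is also large, and a 7.7-fold lower number from compound 2 to compound 3 (0.89 log units; beyond the scatter) is modest. Among the measured compounds shown here, they show that this one position can move the number widely, with smaller groups giving lower numbers and no compound going against that. None of them removes the selenium, however, so no measurement tests this change directly.

A large move towards a higher number in this assay is still expected, to about the level of compound 1 at 8580 nM in this read-out. The expected change is a 140-fold higher number from compound 3 to compound 4 (2.14 log units; beyond the scatter) and it carries wide uncertainty. Compound 4 is estimated at 10000 nM as a middle value, within an expected range from 2000 nM to 50000 nM for its measurement.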

Compound 4, half-maximal inhibitory concentration: 421 nM
The estimate for compound 4 lay 24-fold (1.38 log units) above the measured number; the measured number lies below the stated range.
By their numbers in this assay, from the lowest: compound 3; then compounds 4 and 2 (each within the scatter of the next); then compound 1.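

In this assay the 2-aminoethoxy group, which holds no selenium, still gives a fairly low number, and replacing the selenium-bearing group on this aromatic carbon with it costs only a 5.8-fold higher number from compound 3 to compound 4 (0.76 log units; beyond the scatter) in all. Selenium also proves no guarantee of a low number. Compound 1 and compound 4 both join their chain through an oxygen on the ring, and the change that removes the selenium from the chain end gives a 20-fold lower number from compound 1 to compound 4 (1.31 log units; beyond the scatter) here. Compound 4 and compound 2 cannot be told apart, with a 1.3-fold lower number from compound 2 to compound 4 (0.12 log units; within the scatter) between them, even though only compound 2 carries selenium, so the earlier trend from larger to smaller groups does not separate this pair.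

Nothing shown here explains why these groups give these numbers. From the compounds shown here alone, it remains open what a plain nitrile on the same aromatic carbon would give without any selenium, and whether a longer chain ending in an amine would stay close to compound 4 or move towards compound 1.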